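Removing the 2-carboxyethyl group from compound 1

The source may report more compounds than this note shows. Statements on the series, on what has been measured and on what is new or still open speak of the compounds shown alone.

In a functional assay for inhibition, with Mus musculus as the target (a higher number here means a weaker inhibitor, a lower number a stronger inhibitor), compound 1 `C#CCN(Cc1ccc2nc(C)nc(O)c2c1)c1ccc(C(=O)N[C@@H](CCC(=O)O)C(=O)N(C)[C@@H](CCC(=O)O)C(=O)O)cc1` gives 2200 nM. Compound 2 `C#CCN(Cc1cc2c(O)nc(C)nc2cc1C)c1ccc(C(=O)N[C@@H](CCC(=O)O)C(=O)N(C)[C@@H](CCC(=O)O)C(=O)O)c(F)c1` gives 1400 nM, and compound 3 `C#CCN(Cc1ccc2nc(C)nc(O)c2c1)c1ccc(C(=O)N[C@@H](CC(C)(C)C(=O)O)C(=O)N[C@@H](CCC(=O)O)C(=O)O)cc1` gives 1200 nM. These three numbers lie within the usual scatter of one another, so compound 1 cannot be separated from either of the other two.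

Compound 4 `C#CCN(Cc1ccc2nc(C)nc(O)c2c1)c1ccc(C(=O)N[C@@H](CCC(=O)O)C(=O)N(C)CC(=O)O)cc1` has not yet been measured. It differs from compound 1 by hydrogen in place of 2-carboxyethyl on a saturated chain carbon bound to an amide-type nitrogen and a carbonyl carbon, with hydrogen in place of 2-carboxyethyl on a saturated chain carbon bound to an amide-type nitrogen and a carbonyl carbon. Cut one bond further out, the same difference reads 1,3-dicarboxypropyl to carboxymethyl. Going by the values given here, no measured pair isolates this change, and all three measured compounds retain the 2-carboxyethyl group at this place, so the data offer no direct guide. In this assay, a small move towards a higher number is therefore expected, not clearly beyond the scatter. The estimated step is a 1.3-fold higher number from compound 1 to compound 4 (0.10 log units; within the scatter). For compound 4, the estimated value is 2800 nM, with an expected range from 900 nM to 9000 nM.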

Compound 4, half-maximal inhibitory concentration: 7400 nM
Compound 4: the middle estimate sits 2.6-fold (0.42 log units) below what was measured; low and high end bracket the measured number.
By their numbers in this assay, from the lowest: compounds 3, 2 and 1 (each within the scatter of the next); then compound 4.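

In this assay, hydrogen in place of 2-carboxyethyl on the saturated chain carbon bound to an amide-type nitrogen and a carbonyl carbon gives a 3.4-fold higher number from compound 1 to compound 4 (0.53 log units; beyond the scatter), a modest step but one beyond the scatter. Going by these compounds alone, all the earlier compounds kept the group at this place, so this is the first sign that the position is sensitive to this change, and the number moves towards weaker inhibition when the group is lost. Nothing measured here accounts for the step.

The compounds shown do not tell whether a longer chain or an amine in place of 2-carboxyethyl would keep the number of compound 1. Nor do they tell whether the same removal would give a similar step alongside the other changes carried by compound 2 or compound 3.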